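Aryl versus ethyl on the ring amide nitrogen

A few compounds are considered here, and "the series" means these few. Any claim that something is new, unique, unknown or untested is made for them only; others in the source may bear on it.

Compound 3 `CCN1C(=O)CSC1c1cccc(C(=O)NCCCCc2ccccc2)c1` gives 0% in a functional assay on HOS-TE85 cells (Homo sapiens) for inhibition, read by CCK-8 assay, with a stated time of 72 h, tested at 1 uM (on this read-out higher numbers stand for more inhibition at the one concentration tested (going by the name of the read-out) and lower numbers for less inhibition), and is the lowest of the three numbers in hand. Compound 1 `COc1ccc(F)cc1N1C(=O)CSC1c1cccc(C(=O)NCCCCc2ccccc2)c1` gives 95% and compound 2 `O=C(NCCCCc1ccccc1)c1cccc(C2SCC(=O)N2c2ccccc2)c1` gives 96%; both carry an aromatic group on the amide-type nitrogen in the ring where compound 3 carries ethyl. Going by the values given here, the steps that bear on the change were both large: a number 95 percentage points lower from compound 1 to compound 3 (beyond the scatter) and a number 96 percentage points lower from compound 2 to compound 3 (beyond the scatter). Compound 4 `O=C(NCCCCc1ccccc1)c1cccc(C2SCC(=O)N2c2ccccc2F)c1` differs from compound 3 by 2-fluorophenyl in place of ethyl on an amide-type nitrogen in a ring. This runs opposite to a number 96 percentage points lower from compound 2 to compound 3 (beyond the scatter), with one fluorine added on the entering ring, so a large rise in this assay is expected. The step expected for compound 4 is a number 93 percentage points higher from compound 3 to compound 4 (beyond the scatter). Compound 4 is estimated at 93%, between 78% and 99%.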

Compound 4, a percentage reported as inhibition, at one concentration (the size of the read-out at that concentration, not a potency): 95%
The estimate for compound 4 lay 2 percentage points below the measured number, and the stated range covers the measured number.
By their numbers in this assay, from the lowest: compound 3; then compounds 1, 4 and 2 (each within the scatter of the next).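

In this assay the change from ethyl to 2-fluorophenyl gives a number 95 percentage points higher from compound 3 to compound 4 (beyond the scatter) and extends the contrast between ethyl and aromatic groups on this nitrogen to a third aromatic group. Fluoro in place of hydrogen on an aromatic carbon gives a number 1 percentage points lower from compound 2 to compound 4 (within the scatter) and 2-fluorophenyl in place of 5-fluoro-2-methoxyphenyl gives no change at the digits printed from compound 1 to compound 4 (within the scatter) so these three aromatic groups cannot be told apart here. Nothing available explains this difference between ethyl and the aromatic groups.

On these data alone, whether benzyl, cyclohexyl or pyridyl on this nitrogen would behave like ethyl or like phenyl remains open. Any order among compounds 1, 2 and 4 at lower concentrations also remains open.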